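Replacing ethoxy with acetamido on the aryl ring

This account rests on a few compounds, and the source may have more. Where it says the series, first, only, none or still open, it means among the compounds named here.

Measured so far:
Compound 1 `N#Cc1c(N)nc(SCC(N)=O)c(C#N)c1-c1ccc(OCC2CC2)cc1` gives 31 nM in a functional assay on CHO cells for agonist activity at adenosine receptor A2b (Homo sapiens), read by AlphaScreen and cAMP accumulation; on this read-out lower numbers stand for an effect already at smaller amounts and higher numbers for an effect only at larger amounts of compound.
Compound 2 `CCOc1ccc(-c2c(C#N)c(N)nc(SCc3ccn[nH]3)c2C#N)cc1` gives 332 nM in this assay.
Compound 3 `CCOc1ccc(-c2c(C#N)c(N)nc(SCC(N)=O)c2C#N)cc1` gives 38 nM in this assay.

Compound 3 holds the second highest of the three numbers. Its nearest neighbour is compound 1: the step of a 1.2-fold higher number from compound 1 to compound 3 (0.09 log units; within the scatter) lies within the scatter. The distance to compound 2 is larger, with an 8.7-fold lower number from compound 2 to compound 3 (0.94 log units; beyond the scatter), a change on the sulfur-bound chain.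

Compound 4 `CC(=O)Nc1ccc(-c2c(C#N)c(N)nc(SCC(N)=O)c2C#N)cc1` is the next structure. Its difference from compound 3 is acetamido in place of ethoxy on an aromatic carbon. Within the data shown here, only the step from compound 1 to compound 3 touches the same aromatic carbon, and it was within the scatter; the step from compound 2 to compound 3 concerns another part of the molecule and does not bear on this change. Among the measured compounds shown here, no measured pair exchanges an oxygen-linked group for a nitrogen-linked one on this ring, so the direction is uncertain. The expected step of a 2.1-fold higher number from compound 3 to compound 4 (0.32 log units; beyond the scatter) is therefore small, if any beyond the scatter, with a lean toward a higher number. Compound 4 is estimated at 80 nM in this assay, within a range from 20 nM to 400 nM.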

Compound 4, half-maximal effective concentration: 164 nM
The estimate for compound 4 lay 2.1-fold (0.31 log units) below the measured number, and the stated range covers the measured number.
By their numbers in this assay, from the lowest: compounds 1 and 3 (each within the scatter of the next); then compound 4; then compound 2.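

Compounds 1 and 3 showed only that cyclopropylmethoxy and ethoxy lie within the scatter of each other on this aromatic carbon, para to a large group; compound 4 shows that the number at this place can move beyond the scatter. In this assay, acetamido in place of ethoxy gives a 4.3-fold higher number from compound 3 to compound 4 (0.64 log units; beyond the scatter), and acetamido in place of cyclopropylmethoxy gives a 5.3-fold higher number from compound 1 to compound 4 (0.72 log units; beyond the scatter). No supporting information is available to explain this shift.

The compounds shown leave open whether a plain amine or a longer amide chain on this carbon would give a number closer to those of compound 1 and compound 3. They also leave open whether acetamido would have a similar effect with 1H-pyrazol-5-yl in place of carbamoyl on the sulfur-bound chain.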